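The source may report more compounds than this note shows. Statements on the series, on what has been measured and on what is new or still open speak of the compounds shown alone.

Measured compounds in a functional assay on NCI-H2122 cells (Homo sapiens) for inhibition, read by microscopy, with a stated time of 10 days; a higher number here means a weaker inhibitor, a lower number a stronger inhibitor:
compound 1 `Cc1nn(C)c2c1C(c1ccc3c(c1)OCCO3)C(C#N)=C(N)O2` gives 8600 nM
compound 2 `Cn1nc(-c2ccccc2)c2c1OC(N)=C(C#N)C2c1ccc2c(c1)OCCO2` gives 8400 nM
compound 3 `Cc1nn(C)c2c1C(c1cccc(Br)n1)C(C#N)=C(N)O2` gives 2400 nM

Compound 2 differs from compound 1 by phenyl in place of methyl on an aromatic carbon. This change is measured as a 1.0-fold lower number from compound 1 to compound 2 (0.01 log units; within the scatter), so the two values show no change that can be read. Compound 3 gives the lowest number of the three, and its distances to compound 1 and compound 2 are beyond the scatter. The difference between the core of compound 3 and the core of compound 1 is not broken down here.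

Compound 4 `Cn1nc(-c2ccccc2)c2c1OC(N)=C(C#N)C2c1cccc(Br)n1`, still to be measured, differs from compound 3 by phenyl in place of methyl on an aromatic carbon, the same change at the same place as from compound 1 to compound 2. Because a 1.0-fold lower number from compound 1 to compound 2 (0.01 log units; within the scatter) lay within the scatter, the step from compound 3 to compound 4 in this assay is expected to be about as small, namely no change at the digits printed from compound 3 to compound 4 (within the scatter). Compound 4 is therefore estimated at 2400 nM, with the likely range from 1000 nM to 6000 nM; this rests on a single earlier pair only.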

Compound 4, half-maximal inhibitory concentration: 1700 nM
Compound 4: middle estimate off by 1.4-fold (0.15 log units), on the high side, within the range that was stated.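

In this assay phenyl in place of methyl on an aromatic carbon again gives a step within the scatter (a 1.4-fold lower number from compound 3 to compound 4 (0.15 log units; within the scatter)), so the second core repeats the first. The two steps do not separate: the same change on two cores in this assay, a 1.0-fold lower number (0.01 log units; within the scatter) from compound 1 to compound 2 and a 1.4-fold lower number (0.15 log units; within the scatter) from compound 3 to compound 4, 1.4-fold (0.14 log units) apart, within the scatter of two such steps. On these two cores the change carries over with no readable effect on the number, but this rests on two pairs in one assay and does not show that it would hold on any other core.

The compounds shown leave open whether a group other than methyl or phenyl at this place, such as an amine, a carboxylic acid or a longer chain, would move the number. They also leave open whether a substituted phenyl would behave as phenyl does.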